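Benzyl in place of isobutyl on the thienyl ester

This account rests on a few compounds, and the source may have more. Where it says the series, first, only, none or still open, it means among the compounds named here.

Compound 3, with the structure `CC1=C(C(=O)OCC(C)C)C(c2cccs2)NC(=O)N1`, was measured in an assay on membranes from CHO cells for displacement of a labelled ligand from adenosine receptor A1 (Homo sapiens), read by scintillation counting, with a stated time of 60 min, tested at 1 uM (a lower number here means less inhibition, a higher number more inhibition at the concentration tested (going by the name of the read-out)), where compound 3 gives 25%. Among the three measured compounds it stands second highest. The highest is compound 1, `CC1=C(C(=O)OCc2ccccc2)C(c2ccco2)NC(=O)N1`, which gives 36% in this assay; the lowest is compound 2, `COC(=O)C1=C(C)NC(=O)NC1c1cccs1`, which gives 6%. Compound 1 differs from compound 3 in two places, so its two values are merely compared here without a single step between them.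

Compound 4, `CC1=C(C(=O)OCc2ccccc2)C(c2cccs2)NC(=O)N1`, is the next compound, not yet measured. It differs from compound 3 by phenyl in place of isopropyl on a saturated chain carbon bound to an oxygen next to a carbonyl group. Among the compounds with values here, the only measured step at the same place is a number 19 percentage points higher from compound 2 to compound 3 (beyond the scatter), where a larger group at that chain carbon went together with a higher number. Compound 4 carries the same ester group as compound 1, and compound 1 gives the highest value of the three. Both observations point the same way, though only one of them is a clean single step.

Compound 4 is therefore expected to show a modest rise, a number 10 percentage points higher from compound 3 to compound 4 (within the scatter), in this assay. The estimated value for compound 4 is 35%, with a range from 20% to 50%.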

Compound 4, a percentage reported as inhibition, at one concentration (the size of the read-out at that concentration, not a potency): 45%
For compound 4 the middle estimate is 10 percentage points below the measured one; the range from low to high includes it.
By their numbers in this assay, from the lowest: compound 2; then compound 3; then compounds 1 and 4 (each within the scatter of the next).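

With the thiophen-2-yl group held fixed, phenyl in place of isopropyl on the saturated chain carbon bound to an oxygen next to a carbonyl group gives a number 20 percentage points higher from compound 3 to compound 4 (beyond the scatter) in this assay and phenyl in place of hydrogen at that carbon gives a number 39 percentage points higher from compound 2 to compound 4 (beyond the scatter) in the same measurement. This position now carries three groups in a single series, and the number climbs from hydrogen through isopropyl to phenyl, with none of the three compounds going against that order. Within the data shown here, the first single step at the saturated ring carbon, thiophen-2-yl in place of furan-2-yl, reads a number 9 percentage points higher from compound 1 to compound 4 (within the scatter) and so does not tell the two rings apart while the benzyl ester is in place.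

How a cyclohexyl group or a longer chain would read at the ester position stays open, so the compounds shown do not separate the ring of phenyl from the larger number of carbon atoms it brings. Nothing measured here offers a reason for either step at the ester position or for the reading at the ring carbon.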